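Swapping the oxime-bearing group on a shared core

The source may hold more compounds than are shown below. What is called first, only, known or untested is meant among the compounds shown, and "the series" means these compounds.

Measured compounds:
compound 1, `CN(C)/C(=N\O)c1ccc(Sc2cc(F)cc(C3CCOCC3)c2)cc1`, 280 nM
compound 2, `COC(=O)C(C)(C)CO/N=C(\C)c1ccc(Sc2cc(F)cc(C3CCOCC3)c2)cc1`, 420 nM
compound 3, `O/N=C(/c1ccc(Sc2cc(F)cc(C3CCOCC3)c2)cc1)C(F)(F)F`, 280 nM

All three compounds share one core and differ only in the group carried on the aromatic carbon where the oxime sits. In a functional assay (blood) for inhibition, with Homo sapiens as the target (on this read-out lower numbers stand for stronger inhibition and higher numbers for weaker inhibition), compound 3 gives 280 nM. Compound 3 stands level with compound 1 at the digits shown, and the two together hold the lowest numbers of the three; compound 2 gives 420 nM, which lies within the scatter of the other two, so no order among them can be claimed.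

Compound 4, `C/C(=N\OC(=O)N(C)C)c1ccc(Sc2cc(F)cc(C3CCOCC3)c2)cc1`, has not been measured. It differs from compound 3 in one place: a group of 9 heavy atoms (5 carbon, 2 nitrogen, 2 oxygen; no ring) in place of a group of 7 heavy atoms (2 carbon, 1 nitrogen, 1 oxygen, 3 fluorine; no ring), on an aromatic carbon.

Among the compounds with values here, only one measured step touches this position: no change at the digits printed from compound 1 to compound 3 (within the scatter). That step also exchanged the group on the carbon with a double bond to nitrogen, and the number did not move. Compound 2, with yet another group at this position, also sits within the scatter. On this evidence the change to compound 4 is expected to give no step beyond the scatter, a 1.3-fold higher number from compound 3 to compound 4 (0.10 log units; within the scatter).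

Compound 4 is therefore estimated to give 350 nM in this assay, with a range from 150 nM to 900 nM.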

Compound 4, half-maximal inhibitory concentration: 2610 nM
Estimate against measurement, compound 4: 7.5-fold (0.87 log units) below; measured number above the stated range.
By their numbers in this assay, from the lowest: compounds 1, 3 and 2 (each within the scatter of the next); then compound 4.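

The three earlier compounds made this position look forgiving, but in this assay it clearly is not: the move to the group in compound 4 gives a 9.3-fold higher number from compound 3 to compound 4 (0.97 log units; beyond the scatter) and, by the same margin, a 9.3-fold higher number from compound 1 to compound 4 (0.97 log units; beyond the scatter) on the shared core. The most telling comparison is a 6.2-fold higher number from compound 2 to compound 4 (0.79 log units; beyond the scatter) with only the group on the oxime oxygen changing, dimethylcarbamoyl in place of 2-(methoxycarbonyl)-2-methylpropyl, so that oxygen tolerates one large group far better than the other and size alone does not settle the outcome, since a sizeable group there in compound 2 still stays within the scatter of compounds 1 and 3. Nothing measured here explains why this group costs so much.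

The compounds shown leave open which part of dimethylcarbamoyl carries the step, since an acetyl group on the same oxygen would keep the carbonyl without the dimethylamino end, while a plain methyl there would lose both. They also leave open how a longer chain ending in an amine or a carboxylic acid would fare on that oxygen.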